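The source may report more compounds than this note shows. Statements on the series, on what has been measured and on what is new or still open speak of the compounds shown alone.

Measured in a functional assay on SiHa cells (Homo sapiens) for inhibition, read by CCK-8 assay, with a stated time of 72 h, tested at 10 uM; a lower number here means less inhibition of growth, a higher number more inhibition of growth at the concentration tested:
Compound 1 `CN(C)C(=O)c1cc2cnc(Nc3ccc(NC(=O)C4(C(=O)Nc5cccc(O)c5)CC4)cc3)nc2n1C1CCCC1`: 75.7%
Compound 2 `Nc1ccc(NC(=O)C2(C(=O)Nc3ccc(F)cc3)CC2)cc1F`: 36%

For the measured compounds named here, only these two compounds have numbers so far. Compound 1 holds the higher one, and compound 2 sits lower by a gap beyond the usual scatter of this assay. The open question concerns compound 3 `Cc1ccc(NC(=O)C2(C(=O)Nc3ccc(Nc4ncc5cc(C(=O)N(C)C)n(C6CCCC6)c5n4)cc3)CC2)cc1`, which keeps the shared core of compound 1 and alters one group. The change is 4-methylphenyl in place of 3-hydroxyphenyl on an amide-type nitrogen. Going by the values given here, no measured pair shows what a swap of this kind does, so any forecast here is loose. Compound 1 at 75.7% already lies well up the scale, which leaves less room for a rise than for a fall. A change of one outer group on an otherwise unchanged molecule gives no firm reason to expect a large move in either direction. The expected result is a number 7.7 percentage points lower from compound 1 to compound 3 (within the scatter), a slight fall that would probably not pass beyond the scatter. For compound 3 the estimated value is 68%, with an expected range from 45% to 88%.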

Compound 3, percent growth inhibition at one concentration: 104%
For compound 3 the middle estimate is 36 percentage points below the measured one, outside the stated range (above it).
By their numbers in this assay, from the lowest: compound 2; then compound 1; then compound 3.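

In this assay, putting 4-methylphenyl in place of 3-hydroxyphenyl on the amide-type nitrogen gives a number 28.3 percentage points higher from compound 1 to compound 3 (beyond the scatter), the first measured sign that the group at this position can shift the read-out. The hydrogen-bond donor and acceptor of 3-hydroxyphenyl are absent from 4-methylphenyl, and compound 3 still gives 104%, so neither is required at this position for growth inhibition in this assay. Nothing measured here explains why the number rose.

The single swap changes two things at once: the hydroxyl gives way to a methyl, and the number of the ring position moves from 3 to 4, so the compounds shown cannot tell which of these accounts for the step. A plain phenyl group, 4-hydroxyphenyl or 3-methylphenyl on the same nitrogen would help separate the two, and a longer chain such as 4-ethylphenyl would show whether the rise continues beyond the methyl.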